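A few compounds are considered here, and "the series" means these few. Any claim that something is new, unique, unknown or untested is made for them only; others in the source may bear on it.

Measured so far in a functional assay on UACC-257 cells (Homo sapiens) for inhibition, read by sulforhodamine B assay, with a stated time of 48 h; a lower number here means a stronger inhibitor of growth, a higher number a weaker inhibitor of growth:
- compound 1 `COc1cc(-c2cc(/C=C/C(=O)c3ccc(N)cc3)[nH]n2)cc(OC)c1OC`: 4020 nM
- compound 2 `COc1ccc(-c2cc(/C=C/C(=O)c3ccc(N)cc3)[nH]n2)cc1OC`: 19500 nM

Compound 1 stands lowest of the two numbers. Going by the values given here, the single step, a 4.9-fold higher number from compound 1 to compound 2 (0.69 log units; beyond the scatter), accompanies hydrogen in place of methoxy on an aromatic carbon; it is modest but lies beyond the scatter, so this assay does register changes of that kind on the shared core.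

Compound 3 `COc1cc(-c2cc(/C=C/C(=O)c3ccc(F)c(F)c3)[nH]n2)cc(OC)c1OC` differs from compound 1 by 3,4-difluorophenyl in place of 4-aminophenyl on a carbonyl carbon. No measured pair varies the group on the carbonyl carbon, so no measured step bears on this change; the one step shown, a 4.9-fold higher number from compound 1 to compound 2 (0.69 log units; beyond the scatter), sits on another part of the molecule. The expectation for compound 3 therefore rests on compound 1 alone and carries a wide range. In this assay compound 3 is estimated at 4000 nM, with a range from 1000 nM to 16000 nM. The step of a 1.0-fold lower number from compound 1 to compound 3 (0.00 log units; within the scatter) is expected to be no larger than the scatter, in no settled direction.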

Compound 3, concentration for total growth inhibition: 6280 nM
For compound 3 the middle estimate is 1.6-fold (0.20 log units) below the measured one; the measured number falls inside the stated range.
By their numbers in this assay, from the lowest: compounds 1 and 3 (each within the scatter of the next); then compound 2.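

In this assay, the group on the carbonyl carbon now has its first measured change: a 1.6-fold higher number from compound 1 to compound 3 (0.19 log units; within the scatter) accompanies 3,4-difluorophenyl in place of 4-aminophenyl. For this pair, exchanging a group with one hydrogen-bond donor and one acceptor for a group with neither leaves a step that does not go beyond the scatter, so the donor and acceptor counted on 4-aminophenyl are not required to keep the number in this range. No supporting data bear on why this change registers so little.

Going by these compounds alone, only two groups have been compared at this position, both aromatic, so the reading may not extend to a cyclohexyl group or a 4-carboxyphenyl group on the carbonyl carbon. From the compounds shown here alone, it also remains open whether hydrogen in place of methoxy would give a comparable step with 3,4-difluorophenyl present.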